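The source may report more compounds than this note shows. Statements on the series, on what has been measured and on what is new or still open speak of the compounds shown alone.

Measured compounds in a physicochemical assay for solubility, measured as thermodynamic solubility, with a stated time of 24 h, at pH 6.8; a higher number here means a more soluble compound, a lower number a less soluble compound:
Compound 1, `Cc1cc(C)c2cc(C(=O)NC3CCCCC3)[nH]c2c1`, sits at a limit of the assay, < 4000 nM.
Compound 2, `Cc1cc(C)c2cc(C(=O)NC3CCN(C)CC3)[nH]c2c1`, sits at a limit of the assay, > 10000000 nM.
Compound 3, `CCC(CC)NC(=O)c1cc2c(C)cc(C)cc2[nH]1`, sits at a limit of the assay, < 4000 nM.

Compound 3 thus stands only at a limit in this assay, the same reading as compound 1 (the limit of < 4000 nM in this assay, at which 2 of the 3 values shown sit). Compound 2 alone sits at the opposite limit (the limit of > 10000000 nM in this assay, at which 1 of the 3 values shown sits).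

The next step is to compound 4, `Cc1cc(C)c2cc(C(=O)NC3CCCCCC3)[nH]c2c1`: cycloheptyl in place of pentan-3-yl on an amide-type nitrogen. The closest measured comparison is a step that the two limits leave unreadable from compound 1 to compound 3, an exchange of one carbon-only group for another, which the two limits leave unreadable. Among the compounds with values here, the large steps, an at least 2500-fold higher number from compound 1 to compound 2 (3.39 log units; beyond the scatter) and an at least 2500-fold lower number from compound 2 to compound 3 (3.39 log units; beyond the scatter), both involve the 1-methylpiperidin-4-yl group, which plays no part in the step to compound 4. Cyclohexyl and pentan-3-yl on the amide-type nitrogen both leave their compounds at the lower limit, and cycloheptyl is expected to do the same. The step from compound 3 to compound 4 in this assay is therefore expected to be a step that the limit leaves unreadable from compound 3 to compound 4, nothing beyond the scatter. Compound 4 is estimated at 1500 nM in this assay. The expected range for compound 4 runs from 300 nM to 4000 nM.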

Compound 4, solubility: < 4000 nM
Compound 4 gave a limit, no number; the forecaster's own chance of this, stated with the estimate: 85%; the middle value lies beyond the limit too.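

With cycloheptyl on the amide-type nitrogen, a third carbon-only group, after cyclohexyl and pentan-3-yl, reads at the lower limit in this assay: the limit of < 4000 nM in this assay, at which 3 of the 4 values shown sit.

The steps among compound 1, compound 3 and compound 4 cannot be read, as all three values are limits, so no order among these groups can be stated. Within the data shown here, the one readable new step is an at least 2500-fold lower number from compound 2 to compound 4 (3.39 log units; beyond the scatter), which leaves compound 2 as the only one of the four compounds away from the lower limit.

From the compounds shown here alone, how far the three carbon-only compounds lie beyond that limit stays open. Also open, going by these compounds, is whether the step seen with compound 2 needs the 1-methylpiperidin-4-yl group as a whole, or whether another group on the amide-type nitrogen, such as an open-chain amine or a carboxylic acid, would also leave the lower limit.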